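The source may hold more compounds than are shown below. What is called first, only, known or untested is meant among the compounds shown, and "the series" means these compounds.

In a functional assay on HepG2 cells (Homo sapiens) for antiproliferative activity, read by MTT assay, with a stated time of 72 h (on this read-out higher numbers stand for weaker inhibition and lower numbers for stronger inhibition), compound 1 (`CN(C)CCn1cccc1/C=N/NC(=O)Nc1ccc(Oc2ccnc3[nH]ccc23)c(F)c1`) gives 8980 nM, compound 2 (`CCN(CC)CCCn1cccc1/C=N/NC(=O)Nc1ccc(Oc2ccnc3[nH]ccc23)c(F)c1`) gives 2140 nM and compound 3 (`CN1CCN(CCCn2cccc2/C=N/NC(=O)Nc2ccc(Oc3ccnc4[nH]ccc34)c(F)c2)CC1`) gives 2740 nM. Compound 3 therefore lies within the scatter of compound 2 and beneath compound 1. Compound 4 (`O=C(N/N=C/c1cccn1CCCN1CCCC1)Nc1ccc(Oc2ccnc3[nH]ccc23)c(F)c1`) differs from compound 3 at one place: pyrrolidin-1-yl in place of 4-methylpiperazin-1-yl on a saturated chain carbon, three bonds along the chain from an aromatic nitrogen. Pyrrolidin-1-yl takes the place of 4-methylpiperazin-1-yl on a saturated chain carbon, three bonds along the chain from an aromatic nitrogen. For the measured compounds named here, the one measured swap at that place, a 1.3-fold higher number from compound 2 to compound 3 (0.11 log units; within the scatter), stayed within the scatter. The larger steps, a 4.2-fold lower number from compound 1 to compound 2 (0.62 log units; beyond the scatter) and a 3.3-fold lower number from compound 1 to compound 3 (0.52 log units; beyond the scatter), both start from dimethylamino and bear less directly on this change. No step beyond the scatter is therefore expected in this assay, and the expected step is a 1.1-fold lower number from compound 3 to compound 4 (0.04 log units; within the scatter). Compound 4 is estimated at 2500 nM, with an expected range of 1200 nM to 5200 nM.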

Compound 4, half-maximal inhibitory concentration: 3500 nM
Compound 4: middle estimate off by 1.4-fold (0.15 log units), on the low side; measured number inside the range.
By their numbers in this assay, from the lowest: compounds 2, 3 and 4 (each within the scatter of the next); then compound 1.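

Both a 1.3-fold higher number from compound 3 to compound 4 (0.11 log units; within the scatter) and a 1.6-fold higher number from compound 2 to compound 4 (0.21 log units; within the scatter) stay within the scatter, so at this place pyrrolidin-1-yl, a five-membered ring with 1 hetero atom, reads no differently from 4-methylpiperazin-1-yl or diethylamino. Only a 2.6-fold lower number from compound 1 to compound 4 (0.41 log units; beyond the scatter) goes beyond the scatter, which leaves compound 1 standing apart from the other three. Nothing available explains these numbers.

On these data alone, it remains open whether the gap to compound 1 follows its dimethylamino group or its shorter chain, which dimethylamino on a propyl chain could separate. As far as these compounds go, how a morpholine ring would read at this place is also open.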